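The compounds below may be only part of what the source reports. "The series", "measured", "known", "first", "only" and "open" are said of these compounds alone.

In a functional assay on HCT-116 cells (Homo sapiens) for cytotoxicity, read by MTT assay, with a stated time of 48 h (on this read-out higher numbers stand for weaker inhibition and lower numbers for stronger inhibition), compound 1 `COc1ccc2[nH]c(-c3ccccc3F)cc(=O)c2c1O` gives 50 nM, while compound 2 `COc1cc2c(=O)cc(-c3ccccc3F)[nH]c2cc1O` gives 5800 nM. Compound 2 therefore stands as the higher of the two numbers, the weaker inhibitor by a gap well beyond the scatter. Compound 3 `COc1cc2c(=O)cc(-c3cccc(F)c3)[nH]c2cc1O` keeps the core of compound 2 and carries 3-fluorophenyl in place of 2-fluorophenyl on an aromatic carbon, next to the ring nitrogen (3-fluorophenyl in place of 2-fluorophenyl on an aromatic carbon). Both measured compounds carry 2-fluorophenyl, so the series holds no measured comparison of the two fluorophenyl groups. With nothing to indicate a large shift in this assay, only a small move towards a lower number is expected, none of it beyond the scatter. The estimate is a 1.9-fold lower number from compound 2 to compound 3 (0.29 log units; within the scatter). For compound 3 the expected value is 3000 nM, with an estimated range of 700 nM to 12000 nM.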

Compound 3, half-maximal inhibitory concentration: 1100 nM
Estimate against measurement, compound 3: 2.7-fold (0.44 log units) above; the measured number falls inside the stated range.
By their numbers in this assay, from the lowest: compound 1; then compound 3; then compound 2.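

In this assay, 3-fluorophenyl in place of 2-fluorophenyl gives a 5.3-fold lower number from compound 2 to compound 3 (0.72 log units; beyond the scatter) and so shows that this aromatic carbon, next to the ring nitrogen, is sensitive to the substitution pattern of its aryl group. Going by these compounds alone, the leaving and entering groups have the same atoms and the same counts, so the read-out here responds to where the fluorine sits on the phenyl ring, a point the earlier compounds, which both carry 2-fluorophenyl, could not address. Nothing measured bears on why this step occurs.

From the compounds shown here alone, whether the same exchange has a similar effect on the core of compound 1 remains open. Also open, going by these compounds, is how 4-fluorophenyl, unsubstituted phenyl, or a phenyl carrying chlorine, a methoxy group or an amine would read at this carbon.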